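Triazole side chains on a shared lactone core

The source may hold more compounds than are shown below. What is called first, only, known or untested is meant among the compounds shown, and "the series" means these compounds.

Compounds measured so far in a functional assay on HCT-116 cells (Homo sapiens) for antiproliferative activity, read by MTT assay, with a stated time of 72 h; on this read-out higher numbers stand for weaker inhibition and lower numbers for stronger inhibition:
compound 1 `O=C1O[C@H]([C@@H](O)Cn2cc(CNS(=O)(=O)c3ccc(F)cc3)nn2)C(OCc2ccccc2)=C1OCc1ccccc1` gives 22900 nM
compound 2 `CCCCCc1ccc(-c2cn(C[C@H](O)[C@H]3OC(=O)C(OCc4ccccc4)=C3OCc3ccccc3)nn2)cc1` gives 13800 nM
compound 3 `CCCCCCCCCCc1cn(C[C@H](O)[C@H]2OC(=O)C(OCc3ccccc3)=C2OCc2ccccc2)nn1` gives 28800 nM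

Compound 3 holds the highest number of the three. Its nearest neighbour is compound 1, separated by a 1.3-fold higher number from compound 1 to compound 3 (0.10 log units; within the scatter), so the two cannot be told apart. Compound 2 lies further off, with a 2.1-fold higher number from compound 2 to compound 3 (0.32 log units; beyond the scatter), a modest gap that is real.

Compound 4 `CCCCc1cn(C[C@H](O)[C@H]2OC(=O)C(OCc3ccccc3)=C2OCc2ccccc2)nn1` differs from compound 3 by hydrogen in place of hexyl on a saturated chain carbon, four bonds along the chain from an aromatic carbon. Among the compounds with values here, no measured step shortens a chain in this way. The bearing steps are indirect: replacing the whole sulfonamide-bearing arm with a nonyl chain gave a 1.3-fold higher number from compound 1 to compound 3 (0.10 log units; within the scatter), and replacing a decyl chain with a 4-pentylphenyl ring gave a 2.1-fold higher number from compound 2 to compound 3 (0.32 log units; beyond the scatter). Large changes at this position have moved this assay little, so a trimmed chain is expected to move it little as well, with any shift more likely toward a higher number.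

For compound 4 the estimate is 32000 nM, within a range of 16000 nM to 64000 nM. The expected step is a 1.1-fold higher number from compound 3 to compound 4 (0.05 log units; within the scatter).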

Compound 4, half-maximal inhibitory concentration: 10400 nM
Compound 4: middle estimate off by 3.1-fold (0.49 log units), on the high side; the measured number lies below the stated range.
By their numbers in this assay, from the lowest: compounds 4, 2, 1 and 3 (each within the scatter of the next, the first and the last beyond it).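

In this assay, the butyl and decyl chains isolate chain length at this position: hydrogen in place of hexyl, four bonds along the chain from an aromatic carbon, gives (a 2.8-fold lower number from compound 3 to compound 4 (0.44 log units; beyond the scatter)), so trimming the chain alone moves the number beyond the scatter, and the shorter chain carries the lower number. Compound 4 cannot be told apart from the aryl-bearing analogue (a 1.3-fold lower number from compound 2 to compound 4 (0.12 log units; within the scatter)) but separates from the analogue carrying the ((4-fluorophenyl)sulfonyl)amino arm (a 2.2-fold lower number from compound 1 to compound 4 (0.34 log units; beyond the scatter)), so a butyl group needs no aromatic ring to match compound 2. Nothing available accounts for the shift with chain length.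

Two alkyl chains define no length trend. Still open, on these data alone, are how the number behaves at lengths between butyl and decyl, and whether a methyl group or a chain ending in an amine or a carboxylic acid would match compound 4.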